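A pyridin-4-yl swap on the chain

The source may report more compounds than this note shows. Statements on the series, on what has been measured and on what is new or still open speak of the compounds shown alone.

Compound 1 `COc1cccc(/C=C/C[C@H]2C[C@@H]([C@@H](O)c3ccccc3)CO[C@@H]2c2ccccc2)c1` gives 9620 nM
Compound 2 `O[C@@H](c1ccccc1)[C@H]1CO[C@H](c2ccccc2)[C@@H](C/C=C/c2ccc(F)cc2)C1` gives 8110 nM

In a functional assay on HL-60 cells (Homo sapiens) for cytotoxicity, read by WST assay, with a stated time of 48 h (a lower number here means a stronger inhibitor, a higher number a weaker inhibitor), compound 2 gives 8110 nM and stands within the scatter of compound 1 on the two numbers available. Compound 3 `O[C@@H](c1ccccc1)[C@H]1CO[C@H](c2ccccc2)[C@@H](C/C=C/c2ccncc2)C1` carries pyridin-4-yl in place of 4-fluorophenyl on a double-bonded chain carbon bound to a double-bonded chain carbon. Among the compounds with values here, the one measured step at that place (a 1.2-fold lower number from compound 1 to compound 2 (0.07 log units; within the scatter)) lies within the scatter, and neither compound in it has a ring hetero atom there, so the evidence is thin and no step beyond the scatter is expected. The estimated step is small (a 1.2-fold higher number from compound 2 to compound 3 (0.09 log units; within the scatter)). For compound 3 the estimated value is 10000 nM (expected range 4500 nM to 25000 nM).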

Compound 3, half-maximal inhibitory concentration: > 100000 nM
Compound 3 was reported as a limit; the forecaster's own chance of this, stated with the estimate: 20%; middle value at least 10-fold (1.00 log units) from the limit.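

Until compound 3, changing the ring at this place, on a double-bonded chain carbon bound to a double-bonded chain carbon, had moved the number only within the scatter. In this assay, pyridin-4-yl in place of 4-fluorophenyl gives an at least 12-fold higher number from compound 2 to compound 3 (1.09 log units; beyond the scatter), and in place of 3-methoxyphenyl it gives an at least 10-fold higher number from compound 1 to compound 3 (1.01 log units; beyond the scatter). Compound 3 is reported only as a limit of the assay: the limit of > 100000 nM in this assay, at which 1 of the 3 values shown sits. The compounds shown leave open whether pyridin-3-yl or 4-aminophenyl on the same chain would behave like compound 3 or like compound 2.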